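Chloro Exchanged for Bromo: an Expected Cytotoxicity Step

This account rests on a few compounds, and the source may have more. Where it says the series, first, only, none or still open, it means among the compounds named here.

Of the compounds shown here, two sharing one core have been tested in an ADME assay on HPC cells (Homo sapiens) for cytotoxicity, with a stated time of 48 h; a lower number here means that less compound is tolerated, a higher number that more compound is tolerated. Compound 1 `COc1ccc(/C=C/C(=O)c2c(C)[n+]([O-])c3ccccc3[n+]2[O-])cc1OC` gives 142000 nM there. Compound 2 `Cc1c(C(=O)/C=C/c2ccc(Cl)cc2)[n+]([O-])c2ccccc2[n+]1[O-]` gives 21000 nM in this assay, the lowest of the two numbers; its nearest neighbour, compound 1, stands higher by a gap that lies beyond the scatter. Among the measured compounds shown here, no pair of measured compounds differing in a single place is available, so nothing measured here shows what one small change does to this read-out. Compound 3 `Cc1c(C(=O)/C=C/c2ccc(Br)cc2)[n+]([O-])c2ccccc2[n+]1[O-]` differs from compound 2 in exactly one place: bromo in place of chloro on an aromatic carbon. For the measured compounds named here, with no measured precedent for such an exchange, the step is expected to be no change at the digits printed from compound 2 to compound 3 (within the scatter), that is, no change beyond the scatter in either direction. Compound 3 is therefore expected to give 21000 nM in this assay, with a plausible range from 8000 nM to 55000 nM.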

Compound 3, half-maximal cytotoxic concentration: 43000 nM
The estimate for compound 3 lay 2.0-fold (0.31 log units) below the measured number, within the range that was stated.
By their numbers in this assay, from the lowest: compound 2; then compound 3; then compound 1.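

In this assay, among the compounds shown here, the position on the aromatic carbon, para to a large group, proves responsive to a change of a single halogen: bromo in place of chloro gives a 2.0-fold higher number from compound 2 to compound 3 (0.31 log units; beyond the scatter) and so provides the first single-place step on this core. The step is modest, but it shows that, at this position, 4-bromophenyl is tolerated at higher concentrations than 4-chlorophenyl, so the two halogens cannot be treated as interchangeable here. No measurement available here explains why the number moves.

On these data alone, it remains open whether fluoro or iodo on the same carbon would extend this step in the same direction, or whether the two halogens merely happen to differ. An amine or a carboxylic acid at this position could also move the number either way.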